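A few compounds are considered here, and "the series" means these few. Any claim that something is new, unique, unknown or untested is made for them only; others in the source may bear on it.

Compound 1, `ClCc1ccc(Cn2cnc3c(Cl)ncnc32)cc1`, is the reference point of this account. In a functional assay on SK-OV-3 cells (Homo sapiens) for cytotoxicity, read by sulforhodamine B assay, with a stated time of 48 h (a lower number here means a stronger inhibitor of growth, a higher number a weaker inhibitor of growth), compound 1 gives 13800 nM, the lowest of the two numbers obtained in that assay. Compound 2, `Nc1nc(Cl)c2ncn(Cc3ccccc3CCl)c2n1`, which carries a different core, gives in this assay 52500 nM, a number beyond the scatter from that of compound 1. Compound 3, `ClCc1cccc(Cn2cnc3nc(Cl)nc(Cl)c32)c1`, was prepared, but in this assay compound 3 stands as "not determined" (no result reported), so no result in this assay was obtained for it.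

Compound 4, `ClCc1ccc(Cn2cnc3c(Cl)nc(Cl)nc32)cc1`, is compound 1 with one change: chloro in place of hydrogen on an aromatic carbon. The added chloro sits between two ring nitrogen atoms of the core of compound 1, on a carbon of the six-membered aromatic ring that forms part of the fused two-ring system.

Within the data shown here, no pair of measured compounds differing only in one place is available here, so the size of the step cannot be read from any neighbour. A small step, within or close to the scatter, and if anything toward a lower number is expected, so that the step of a 1.5-fold lower number from compound 1 to compound 4 (0.19 log units; within the scatter) is the estimate. Compound 4 is therefore expected to give about 9000 nM, within a range from 2500 nM to 30000 nM.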

Compound 4, concentration for total growth inhibition: 29500 nM
Estimate against measurement, compound 4: 3.3-fold (0.52 log units) below, within the range that was stated.
By their numbers in this assay, from the lowest: compound 1; then compounds 4 and 2 (each within the scatter of the next).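

In this assay, among these compounds, there is a 2.1-fold higher number from compound 1 to compound 4 (0.33 log units; beyond the scatter) and this is the first step in the account that can be read at a single place: chloro in place of hydrogen on this aromatic carbon, between two ring nitrogen atoms, gives a modest move toward weaker inhibition of growth, beyond the scatter. The earlier compounds shown here could not show this, as compound 1 and compound 2 differ in more than one place and compound 3 has no result. Nothing given here explains the direction of this step.

As far as these compounds go, whether a fluoro, a methyl or a methoxy group on the same carbon would move the number in the same direction remains open. From the compounds shown here alone, it also remains open whether chloro at this position would give a step of similar size with the chloromethyl group elsewhere on the benzyl ring.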